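This account rests on a few compounds, and the source may have more. Where it says the series, first, only, none or still open, it means among the compounds named here.

In an ADME assay on microsomes from liver (Rattus norvegicus) for metabolic stability, with a stated time of 10 min (on this read-out higher numbers stand for a more stable compound and lower numbers for a less stable compound), compound 1 `c1ccc2oc(-c3cn4nc(C5CC5)sc4n3)cc2c1` gives 53%, the highest of the three numbers recorded so far. Compound 3 `COc1cc(OCc2cccc(Oc3ccccc3)c2)c2cc(-c3cn4nc(OC)sc4n3)oc2c1` comes nearest, giving 42%, a gap beyond the usual scatter, while compound 2 `COc1cc(OCc2ccccc2OCc2ccccc2)c2cc(-c3cn4nc(OC)sc4n3)oc2c1` lies furthest away, at 22%. No two of these compounds differ in a single place, so no single step can be drawn among them. Compound 4 `Cc1nn2cc(-c3cc4ccccc4o3)nc2s1` has not yet been measured; it differs from compound 1 in one place: methyl in place of cyclopropyl on an aromatic carbon. Going by the values given here, with no measured step of this kind to lean on, the change is expected to shift the read-out only modestly, as a small step downward, a number 8 percentage points lower from compound 1 to compound 4 (within the scatter), which may well stay within the scatter. Compound 4 is therefore estimated to give 45%, most likely between 25% and 65%.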

Compound 4, percent of the compound remaining: 4%
Compound 4: the middle estimate sits 41 percentage points above what was measured; measured number outside the range, below it.
By their numbers in this assay, from the lowest: compound 4; then compound 2; then compound 3; then compound 1.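

Measured in this assay this single change, methyl in place of cyclopropyl on an aromatic carbon, gives a number 49 percentage points lower from compound 1 to compound 4 (beyond the scatter) and shows that the read-out depends strongly on the group at this position. The earlier compounds shown here, which differ in more than one place, could not show this. Nothing available here explains the fall.

Going by these compounds, it remains open whether the three-membered ring itself matters or only the carbon count, a question that ethyl or isopropyl at this carbon would address. On these data alone, how an amine there would behave also remains unknown.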